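Chloro added to the thiophene of compound 2

The compounds below may be only part of what the source reports. "The series", "measured", "known", "first", "only" and "open" are said of these compounds alone.

Measured so far in a functional assay on Jurkat cells for inhibition of nuclear factor NF-kappa-B complex (Homo sapiens); a lower number here means a stronger inhibitor, a higher number a weaker inhibitor:
Compound 1, `CCOC(=O)c1cnc(C(C)(C)C)nc1NN1C(=O)C=C(C)C1=O`, gives 1000 nM.
Compound 2, `CCOC(=O)c1cnc(-c2cccs2)nc1NN1C(=O)C=C(C)C1=O`, gives 20 nM.
Compound 3, `CCOC(=O)c1cnc(-c2ccc(F)cc2)nc1NN1C(=O)C=C(C)C1=O`, gives 700 nM.

Compound 2 stands lowest of the three numbers in this assay, and both gaps to it lie beyond the scatter: the nearer one is a 35-fold higher number from compound 2 to compound 3 (1.54 log units; beyond the scatter), the wider one is a 50-fold lower number from compound 1 to compound 2 (1.70 log units; beyond the scatter). Both measured steps exchange the whole group on the same aromatic carbon of the shared core, and the thiophen-2-yl of compound 2 stands out from tert-butyl and 4-fluorophenyl by a large margin.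

Compound 4, `CCOC(=O)c1cnc(-c2ccc(Cl)s2)nc1NN1C(=O)C=C(C)C1=O`, is not yet measured. It keeps that thiophen-2-yl and differs from compound 2 only by chloro in place of hydrogen on an aromatic carbon. For the measured compounds named here, no measured step touches this ring itself; the data show only that the ring as a whole matters. With the ring retained, no step beyond the scatter is expected in this assay, in either direction. Compound 4 is therefore estimated at 20 nM, in the range 7 nM to 60 nM, which means an expected no change at the digits printed from compound 2 to compound 4 (within the scatter).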

Compound 4, half-maximal inhibitory concentration: 300 nM
For compound 4 the middle estimate is 15-fold (1.18 log units) below the measured one, outside the stated range (above it).
By their numbers in this assay, from the lowest: compound 2; then compound 4; then compounds 3 and 1 (each within the scatter of the next).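

In this assay, a single chloro in place of hydrogen gives a 15-fold higher number from compound 2 to compound 4 (1.18 log units; beyond the scatter) even though the thiophene stays, so the earlier whole-group exchanges had not shown that one ring carbon, next to the ring sulfur, can matter this much. The 5-chlorothiophen-2-yl still compares well with the other two groups, with a 2.3-fold lower number from compound 3 to compound 4 (0.37 log units; beyond the scatter) and a 3.3-fold lower number from compound 1 to compound 4 (0.52 log units; beyond the scatter) as modest steps, but most of the lead held by compound 2 is gone. No available evidence explains this loss.

The compounds shown leave open whether a methyl or a methoxy on this same carbon would cost as much as chloro. They also leave open whether chloro on another carbon of the thiophene would be better tolerated.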